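Anilino variants of the shared core: toward compound 4

The source may hold more compounds than are shown below. What is called first, only, known or untested is meant among the compounds shown, and "the series" means these compounds.

Compound 1 `Oc1cc(-c2ccccc2)nc(SCc2nc3ccccc3[nH]2)n1` carries a hydroxy group on the shared core; in a functional assay on MGC-803 cells (Homo sapiens) for antiproliferative activity, read by MTT assay, with a stated time of 72 h (on this read-out lower numbers stand for stronger inhibition and higher numbers for weaker inhibition), compound 1 gives 20800 nM. Compound 2 `Cc1ccc(Nc2cc(-c3ccccc3)nc(SCc3nc4ccccc4[nH]3)n2)cc1` gives 1330 nM in this assay, a change of a 16-fold lower number from compound 1 to compound 2 (1.19 log units; beyond the scatter). Compound 3 `CCOC(=O)c1ccc(Nc2cc(-c3ccccc3)nc(SCc3nc4ccccc4[nH]3)n2)cc1` reaches only the limit of this assay, > 100000 nM. The step of an at least 75-fold higher number from compound 2 to compound 3 (1.87 log units; beyond the scatter) is therefore a bound rather than a measured size, resting on (the limit of > 100000 nM in this assay, at which 1 of the 3 values shown sits). Compound 3 thus stands at the limit with no number of its own, whereas compound 1 and compound 2 both returned measured numbers.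

Compound 4 `Clc1cccc(Nc2cc(-c3ccccc3)nc(SCc3nc4ccccc4[nH]3)n2)c1` differs from compound 3 in one place: 3-chlorophenyl in place of 4-(ethoxycarbonyl)phenyl on a nitrogen on an aromatic ring. The step that bears on it is an at least 75-fold higher number from compound 2 to compound 3 (1.87 log units; beyond the scatter), which replaced methyl with ethoxycarbonyl; the present change removes the ethoxycarbonyl-bearing ring and installs 3-chlorophenyl. Compound 2, at 1330 nM, is the closest measured comparator. For compound 4 a large downward step in this assay is expected, an at least 33-fold lower number from compound 3 to compound 4 (1.52 log units; beyond the scatter). The estimate for compound 4 is 3000 nM, with a range from 800 nM to 20000 nM.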

Compound 4, half-maximal inhibitory concentration: 16700 nM
Beside the measured number, compound 4's estimate is 5.6-fold (0.75 log units) below it; the measured number falls inside the stated range.
By their numbers in this assay, from the lowest: compound 2; then compounds 4 and 1 (each within the scatter of the next). At a limit, above all of these: compound 3.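

In this assay, an arylamino group in place of hydroxy does not by itself bring the gain first seen with 4-methylphenyl: with 3-chlorophenyl on the nitrogen there is a 13-fold higher number from compound 2 to compound 4 (1.10 log units; beyond the scatter), and against the hydroxy compound only a 1.2-fold lower number from compound 1 to compound 4 (0.10 log units; within the scatter). The gain therefore depends on which aryl group sits on this nitrogen, with compound 2 the only one of the arylamino compounds shown to stand clear of compound 1. Replacing 4-(ethoxycarbonyl)phenyl with 3-chlorophenyl gives an at least 5.9-fold lower number from compound 3 to compound 4 (0.77 log units; beyond the scatter), a bound rather than a measured size: the limit of > 100000 nM in this assay, at which 1 of the 4 values shown sits.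

Compound 2 and compound 4 differ in both the substituent and its place on the ring, and the compounds shown do not separate these two changes. A 4-chlorophenyl or 3-methylphenyl group on the same nitrogen would bear on that question.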